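Second Bromine on the Hydroxyphenyl Hydrazone

The compounds below may be only part of what the source reports. "The series", "measured", "known", "first", "only" and "open" are said of these compounds alone.

Compound 1 `O=C(CSc1nnc(-c2ccncc2)o1)N/N=C/c1cccc(F)c1` gives 26700 nM in a functional assay on SW 1116 cells (Homo sapiens) for cytotoxicity, read by MTT assay, with a stated time of 48 h; on this read-out higher numbers stand for weaker inhibition and lower numbers for stronger inhibition.
Compound 2 `O=C(CSc1nnc(-c2ccncc2)o1)N/N=C/c1cc(Br)ccc1O` gives 8150 nM in this assay.

In this assay compound 2 holds the lowest of the two numbers; its nearest neighbour, compound 1, lies above it by a 3.3-fold lower number from compound 1 to compound 2 (0.52 log units; beyond the scatter). Compound 3 `O=C(CSc1nnc(-c2ccncc2)o1)N/N=C/c1cc(Br)cc(Br)c1O` differs from compound 2 by bromo in place of hydrogen on an aromatic carbon. Within the data shown here, the only measured step, a 3.3-fold lower number from compound 1 to compound 2 (0.52 log units; beyond the scatter), exchanged the whole aryl ring and so bears only loosely on adding one more bromine. A modest step downward, or none beyond the scatter, is therefore expected in this assay. Compound 3 is estimated at 5000 nM, between 1500 nM and 16000 nM, an expected step of a 1.6-fold lower number from compound 2 to compound 3 (0.21 log units; within the scatter).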

Compound 3, half-maximal inhibitory concentration: 8570 nM
Compound 3: the middle estimate sits 1.7-fold (0.23 log units) below what was measured; measured number inside the range.
By their numbers in this assay, from the lowest: compounds 2 and 3 (each within the scatter of the next); then compound 1.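

In this assay bromo in place of hydrogen, ortho to a hydroxy group, leaves the number within the scatter (a 1.1-fold higher number from compound 2 to compound 3 (0.02 log units; within the scatter)), so this position accepts a second bromine without a step beyond it. The 3,5-dibromo-2-hydroxyphenyl ring stays clear of the 3-fluorophenyl ring (a 3.1-fold lower number from compound 1 to compound 3 (0.49 log units; beyond the scatter)). No available evidence bears on this result. As far as these compounds go, whether chloro, methoxy or an amine at this position would also stay within the scatter remains open, as does what removing the hydroxy group from the dibrominated ring would do.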